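Hydrogen for tert-butyl on a fragment ester oxygen

A few compounds are considered here, and "the series" means these few. Any claim that something is new, unique, unknown or untested is made for them only; others in the source may bear on it.

Compound 1 `Cc1ncsc1-c1ccc(CNC(=O)[C@@H]2C[C@@H](O)CN2C(=O)[C@@H](NC(=O)COCCOCCOc2ccc(Cl)cc2C(=O)Nc2ccc([N+](=O)[O-])cc2Cl)C(C)(C)C)cc1` gives 4940 nM in a functional assay on CWR22R cells (Homo sapiens) for inhibition, read by WST assay, with a stated time of 3 days; a lower number here means a stronger inhibitor, a higher number a weaker inhibitor.
Compound 2 `Cc1ncsc1-c1ccc(CNC(=O)[C@@H]2C[C@@H](O)CN2C(=O)[C@@H](NC(=O)COCCOCCn2cc(CCOc3ccc(Cl)cc3C(=O)Nc3ccc([N+](=O)[O-])cc3Cl)nn2)C(C)(C)C)cc1` gives 6880 nM in this assay.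
Compound 3 `CC(C)(C)OC(=O)COCCOCCn1cc(CCOc2ccc(Cl)cc2C(=O)Nc2ccc([N+](=O)[O-])cc2Cl)nn1` gives only a limit, > 10000 nM, in this assay.

Compound 3 carries the aryl ether, the amide and the triazole-linked chain of compound 2 but ends in a tert-butyl ester rather than the larger assembly. Its measurement does not place it on the scale: it sits at the limit of > 10000 nM in this assay, at which 1 of the 3 values shown sits, so how far it lies from compound 1 and compound 2 is not known.

Compound 4 `O=C(O)COCCOCCn1cc(CCOc2ccc(Cl)cc2C(=O)Nc2ccc([N+](=O)[O-])cc2Cl)nn1` differs from compound 3 by hydrogen in place of tert-butyl on an oxygen next to a carbonyl group. Among the compounds with values here, no measured pair shows this change, and compound 3 itself is only a limit, so no step size can be anchored. For the step from compound 3 to compound 4 nothing beyond the scatter is expected, a step that the limit leaves unreadable from compound 3 to compound 4. Compound 4 is expected to give 15000 nM in this assay, within 5000 nM to 50000 nM, and most likely again only a limit.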

Compound 4, half-maximal inhibitory concentration: > 10000 nM
Compound 4 gave a limit, no number; the forecaster's own chance of this, stated with the estimate: 80%; the middle value lies beyond the limit too.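

In this assay, compound 3 and compound 4 both stand only as limits, so no step between them can be read: the limit of > 10000 nM in this assay, at which 2 of the 4 values shown sit.

The compounds shown leave open how far compound 3 and compound 4 lie from compound 1 and compound 2, and whether hydrogen in place of tert-butyl changes the result at all.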